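Swapping a Cyclopentyl for a Propyl Chain

The compounds below may be only part of what the source reports. "The series", "measured", "known", "first", "only" and "open" are said of these compounds alone.

Measured so far:
compound 1, `Fc1ccc(Cn2nnc3c(Br)cccc32)cc1`: 1 mL/min/g
compound 2, `Brc1cccc2c1nnn2CC1CCCC1`: 11.4 mL/min/g

Of the compounds shown here, two sharing one core have been tested in an ADME assay on microsomes from liver (Mus musculus, strain NMRI) for metabolic stability, tested at 2.5 uM; on this read-out higher numbers stand for fast clearance and lower numbers for slow clearance. Compound 1 gives 1 mL/min/g in this assay, and compound 2 gives 11.4 mL/min/g. Compound 2 thus has the higher of the two numbers, and its gap to compound 1 lies beyond the usual scatter of such measurements.

The next compound is compound 3, `CCCCn1nnc2c(Br)cccc21`. Relative to compound 2 it carries propyl in place of cyclopentyl on a saturated chain carbon bound to an aromatic nitrogen. Among the measured compounds shown here, no measured pair shows the effect of this exact change, so the outlook rests on compound 2 alone.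

For compound 3 in this assay the change from compound 2 is expected to be a 1.6-fold lower number from compound 2 to compound 3 (0.21 log units; within the scatter), a modest drop or none beyond the scatter. Compound 3 is therefore estimated at 7 mL/min/g, with a range from 2.5 mL/min/g to 16 mL/min/g.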

Compound 3, intrinsic clearance in a liver preparation (reported as CLH), per the amount of preparation that the assay uses: 8.3 mL/min/g
The estimate for compound 3 lay 1.2-fold (0.07 log units) below the measured number; low and high end bracket the measured number.
By their numbers in this assay, from the lowest: compound 1; then compounds 3 and 2 (each within the scatter of the next).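

In this assay, putting propyl in place of cyclopentyl on a saturated chain carbon bound to an aromatic nitrogen gives a 1.4-fold lower number from compound 2 to compound 3 (0.14 log units; within the scatter). Among the compounds shown here, this is the first measured change at this position, and it shows that losing the ring and going from 5 carbons to 3 leaves the clearance number within the normal spread of repeat measurements, so these two groups cannot be told apart in this test. Nothing available explains why compound 2 and compound 3 read alike.

Still open, on these data alone, is whether any group at this position can bring the number clearly away from that of compound 2, for instance a longer chain such as hexyl, an amine or a carboxylic acid. A single step also cannot show whether the same swap would behave alike on another core.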